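Cyclopropane substituent: aromatic ring to cyclohexyl in compound 4

This account rests on a few compounds, and the source may have more. Where it says the series, first, only, none or still open, it means among the compounds named here.

Compound 3 `CC[C@H](C)[C@H](N)CN(C(=O)[C@@H]1C[C@H]1c1ccccc1F)c1ccc(-c2ccccc2)cc1` gives 650 nM in a functional assay for agonist activity at G protein-coupled receptor 88 (Homo sapiens), read by HTRF and cAMP accumulation; on this read-out higher numbers stand for an effect only at larger amounts of compound and lower numbers for an effect already at smaller amounts; compound 2 `CC[C@H](C)[C@H](N)CN(C(=O)[C@@H]1C[C@H]1c1ccc(F)cc1)c1ccc(-c2ccccc2)cc1` gives 600 nM, and the two sit within the scatter of each other (a 1.1-fold higher number from compound 2 to compound 3 (0.03 log units; within the scatter)). Compound 1 `CC[C@H](C)[C@H](N)CN(C(=O)[C@@H]1C[C@H]1c1ccccc1Cl)c1ccc(-c2ccccc2)cc1` gives > 25000 nM, which is a limit and not a number (the limit of > 25000 nM in this assay, at which 1 of the 3 values shown sits). The steps of an at least 41-fold lower number from compound 1 to compound 2 (1.61 log units; beyond the scatter) and an at least 38-fold lower number from compound 1 to compound 3 (1.58 log units; beyond the scatter) concern only the halogen on the aromatic ring. Compound 4 `CC[C@H](C)[C@H](N)CN(C(=O)[C@@H]1C[C@H]1C1CCCCC1)c1ccc(-c2ccccc2)cc1` differs from compound 3 by cyclohexyl in place of 2-fluorophenyl on a saturated ring carbon. Among the compounds with values here, no measured step exchanges the aromatic ring for a saturated ring, so the direction is open; the measured steps show this part of the molecule matters strongly. Compound 4 is therefore expected at 3000 nM (range 400 nM to 25000 nM), an estimated step of a 4.6-fold higher number from compound 3 to compound 4 (0.66 log units; beyond the scatter).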

Compound 4, half-maximal effective concentration: > 25000 nM
Compound 4: no number, only a limit (the forecaster's own chance of this, stated with the estimate: 30%); middle value at least 8.3-fold (0.92 log units) from the limit.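

Replacing the aromatic ring with cyclohexyl on this saturated ring carbon gives an at least 38-fold higher number from compound 3 to compound 4 (1.58 log units; beyond the scatter) and an at least 41-fold higher number from compound 2 to compound 4 (1.61 log units; beyond the scatter), so an aromatic ring here appears necessary in this small set, though compound 1 shows that it is not sufficient. In this assay compound 4 gives > 25000 nM, a limit and not a number: the limit of > 25000 nM in this assay, at which 2 of the 4 values shown sit. Compound 1 and compound 4 both sit at this limit, so the step between them cannot be read.

On these data alone, whether pyridyl or cyclopentyl on this carbon would retain a response remains open. As far as these compounds go, the effect of a methoxy group in place of the fluoro on the aromatic ring is also open.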